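This account rests on a few compounds, and the source may have more. Where it says the series, first, only, none or still open, it means among the compounds named here.

Compound 1 `Cc1ccc(-c2cncc(Cl)c2N2CCC3(CCNC3=O)CC2)o1` gives 4950 nM in a functional assay on MV4-11 cells (Homo sapiens) for inhibition, read by resazurin assay, with a stated time of 72 h (a higher number here means a weaker inhibitor of growth, a lower number a stronger inhibitor of growth), the highest of the three numbers here, though its gap to compound 3 `O=C1NCCC12CCN(c1c(Cl)cncc1-c1ccc(CN3CCCCC3)s1)CC2`, at 4010 nM, and to compound 2 `O=C1NCCC12CCN(c1c(Cl)cncc1-c1ccc(CN3CCCC3)s1)CC2`, at 3370 nM, stays within the scatter. Going by the values given here, the only measured step, a 1.2-fold higher number from compound 2 to compound 3 (0.08 log units; within the scatter), concerns a different place in the molecule and lies within the scatter, so it says little about the change now in question. Compound 4 `Cn1cccc1-c1cncc(Cl)c1N1CCC2(CCNC2=O)CC1` differs from compound 1 by 1-methyl-1H-pyrrol-2-yl in place of 5-methylfuran-2-yl on an aromatic carbon: one five-membered aromatic ring with 1 hetero atom gives way to another, the methyl retained. Among the compounds with values here, no measured step exchanges this ring, and nothing here points to a move beyond the scatter. Compound 4 is therefore expected near 5000 nM in this assay, between 2000 nM and 12500 nM. The expected step is a 1.0-fold higher number from compound 1 to compound 4 (0.00 log units; within the scatter).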

Compound 4, concentration for 50% growth inhibition: 900 nM
Beside the measured number, compound 4's estimate is 5.6-fold (0.74 log units) above it; measured number below the stated range.
By their numbers in this assay, from the lowest: compound 4; then compounds 2, 3 and 1 (each within the scatter of the next).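

On an aromatic carbon of a six-membered aromatic ring with 1 nitrogen, the exchange of one five-membered aromatic ring for another is not neutral: this assay records a 5.5-fold lower number from compound 1 to compound 4 (0.74 log units; beyond the scatter). Going by these compounds alone, both groups count the same heavy atoms, donors and acceptors, so these counts do not separate them, whereas the only earlier step stayed within the scatter. Nothing available explains this difference.

Still open, on these data alone, is how the number responds to ethyl in place of the methyl on the 1H-pyrrol-2-yl ring, or to the ring without any alkyl group.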